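Fluoro on compound 2: little change expected

The source may report more compounds than this note shows. Statements on the series, on what has been measured and on what is new or still open speak of the compounds shown alone.

Among the compounds with values here, in a functional assay on MCF7 cells (Homo sapiens) for cytotoxicity, read by MTT assay, with a stated time of 72 h (on this read-out higher numbers stand for weaker inhibition and lower numbers for stronger inhibition), compound 2 (`COc1ccc(-c2ccnc(C(=O)Nc3ccc(Oc4ccnc5[nH]ccc45)cc3)c2)cc1`) gives 8210 nM, the only actual number so far. Compound 1 (`Cc1ccc(-c2ccnc(C(=O)Nc3ccc(Oc4ccnc5[nH]ccc45)cc3)c2)cc1`) reads > 10000 nM, which is a limit of the assay. Compound 3 (`O=C(Nc1ccc(Oc2ccnc3[nH]ccc23)cc1)c1cc(-c2ccc(C(F)(F)F)cc2)ccn1`) reads > 10000 nM, which is also a limit. The series is thus bounded by the limit of > 10000 nM in this assay, at which 2 of the 3 values shown sit.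

Compound 4 (`COc1ccc(-c2ccnc(C(=O)Nc3ccc(Oc4ccnc5[nH]ccc45)c(F)c3)c2)cc1`) differs from compound 2 by fluoro in place of hydrogen on an aromatic carbon, on an aromatic carbon of a six-membered aromatic ring of carbon only. The measured steps bear on this only loosely. They are an at least 1.2-fold lower number from compound 1 to compound 2 (0.08 log units; that floor lies within the scatter) and an at least 1.2-fold higher number from compound 2 to compound 3 (0.08 log units; that floor lies within the scatter), both floors within the scatter, while a step that the two limits leave unreadable from compound 1 to compound 3 gives no size. None of the three puts fluoro in place of hydrogen, so no step beyond the scatter is expected in this assay. The estimate therefore stays anchored on compound 2 at 8210 nM. The expected change is a 1.0-fold lower number from compound 2 to compound 4 (0.01 log units; within the scatter). For compound 4 the estimated value is 8000 nM, with an expected range from 3000 nM to 15000 nM.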

Compound 4, half-maximal inhibitory concentration: 9110 nM
For compound 4 the middle estimate is 1.1-fold (0.06 log units) below the measured one, within the range that was stated.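

In this assay, fluoro in place of hydrogen on this aromatic carbon, ortho to a large group and meta to a large group, gives a 1.1-fold higher number from compound 2 to compound 4 (0.05 log units; within the scatter). The earlier steps all exchanged methyl, methoxy and trifluoromethyl at a different place, so this is the only step shown at this position, and at this size it gives no sign that the position matters for the read-out. Compound 4 adds a second actual number to the series, while the other values remain limits of the assay: the limit of > 10000 nM in this assay, at which 2 of the 4 values shown sit.

On these data alone, whether fluoro at this carbon has the same small effect with methyl or trifluoromethyl in place of methoxy remains open. So does whether chloro, an amine or a carboxylic acid on the same carbon would give a step beyond the scatter.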